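Compound 3 to compound 4: one group exchanged

The compounds below may be only part of what the source reports. "The series", "measured", "known", "first", "only" and "open" are said of these compounds alone.

Compound 1 `COC(=O)c1cc(-c2cccc(NC(=O)c3ccc(/C=C/C(=O)c4cc(OC)c(OC)c(OC)c4)cc3)c2)on1`: > 50 ug/mL
Compound 2 `COC(=O)c1cc(-c2cccc(NC(=O)c3ccc(/C=C/C(=O)c4ccccc4OC)cc3)c2)on1`: > 40 ug/mL
Compound 3 `CCCOc1ccc(C(=O)/C=C/c2ccc(C(=O)Nc3cccc(-c4cc(C(=O)OC)no4)c3)cc2)cc1`: > 40 ug/mL

All three entries come from an ADME assay on Vero cells (Chlorocebus sabaeus) for cytotoxicity, read by MTT assay, with a stated time of 72 h (on this read-out lower numbers stand for higher toxicity in this test and higher numbers for lower toxicity in this test), and each is a limit, not a number. Compound 3 stands at > 40 ug/mL, which is a limit. Across the set, the picture is the limit of > 40 ug/mL in this assay, at which 2 of the 3 values shown sit, alongside (the limit of > 50 ug/mL in this assay, at which 1 of the 3 values shown sits). No order among the three compounds can be read from this.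

Compound 4 `COC(=O)c1cc(-c2cccc(NC(=O)c3ccc(/C=C/C(=O)c4ccc(C)c(F)c4)cc3)c2)on1` keeps the shared core of compound 3 and changes one group: 3-fluoro-4-methylphenyl in place of 4-propoxyphenyl on a carbonyl carbon. In words, 3-fluoro-4-methylphenyl takes the place of 4-propoxyphenyl on a carbonyl carbon.

Three measured exchanges at this same carbonyl carbon bear on the change. They are a step that the two limits leave unreadable from compound 1 to compound 2, a step that the two limits leave unreadable from compound 1 to compound 3 and a step that the two limits leave unreadable from compound 2 to compound 3. None of them has a readable size, so they offer no direction and no magnitude to carry over. On that basis, no step beyond the usual scatter is expected in this assay, in either direction. The expected change is a step that the limit leaves unreadable from compound 3 to compound 4. The assay will quite probably report only a limit again. Compound 4 is estimated at 45 ug/mL, with an expected range from 22 ug/mL to 90 ug/mL.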

Compound 4, half-maximal cytotoxic concentration: > 50 ug/mL
Compound 4 gave a limit, no number; the forecaster's own chance of this, stated with the estimate: 75%; middle value at least 1.1-fold (0.04 log units) away from the limit.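

In this assay compound 4 gives > 50 ug/mL, which is a limit and not a number. Within the data shown here, no step between compound 4 and compound 1, compound 2 or compound 3 can be read. The compounds shown leave open whether any of these exchanges on the carbonyl carbon alters the half-maximal cytotoxic concentration, and in which direction.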